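The source may hold more compounds than are shown below. What is called first, only, known or untested is meant among the compounds shown, and "the series" means these compounds.

Measured compounds:
- compound 1 `CCOc1cccc(S(=O)(=O)Nc2ccc(N3CCN(c4cccc(-c5c(C(=O)NCCCN6CCN(C)CC6)c(C)n(C)c5-c5ccc(Cl)cc5)c4)CC3)cc2)c1` gives 1620 nM in an assay for inhibition of Apoptosis regulator Bcl-2 (Homo sapiens), read by fluorescence polarization, with a stated time of 2 h; on this read-out lower numbers stand for stronger inhibition and higher numbers for weaker inhibition
- compound 2 `Cc1c(C(=O)O)c(-c2cccc(N3CCN(c4ccc(NS(=O)(=O)c5ccc(N[C@H](CCN6CCC(O)CC6)CSc6ccccc6)c(S(=O)(=O)C(F)(F)F)c5)cc4)CC3)c2)c(-c2ccc(Cl)cc2)n1C(C)C` gives 4 nM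
- compound 3 `Cc1c(C(=O)O)c(-c2cccc(N3CCN(c4ccc(NS(=O)(=O)c5ccc(N[C@H](CCN6CC(O)C6)CSc6ccccc6)c(S(=O)(=O)C(F)(F)F)c5)cc4)CC3)c2)c(-c2ccc(Cl)cc2)n1C` gives 7.7 nM

Compound 1 stands at the highest of the three numbers in this assay, with compound 3 nearest and compound 2 furthest; both of these differences lie beyond the scatter, but compounds 2 and 3 differ from compound 1 in several places at once, so none of them shows a single step.

Compound 4 `Cc1c(C(=O)NCCCN2CCN(C)CC2)c(-c2cccc(N3CCN(c4ccc(NS(=O)(=O)c5cccc(S(=O)(=O)C(F)(F)F)c5)cc4)CC3)c2)c(-c2ccc(Cl)cc2)n1C` is the next compound. It differs from compound 1 in one place: (trifluoromethyl)sulfonyl in place of ethoxy on an aromatic carbon, the new group sitting meta to a large group on the same ring that carries the ethoxy in compound 1. Among the compounds with values here, no measured pair isolates this change. The far lower numbers of compounds 2 and 3, which both carry the entering group, cannot be assigned to it alone, so the step is expected to be modest, towards a lower number, and likely beyond the scatter. Compound 4 is expected at 500 nM, within 150 nM to 1600 nM, which means an expected step of a 3.2-fold lower number from compound 1 to compound 4 (0.51 log units; beyond the scatter).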

Compound 4, half-maximal inhibitory concentration: 153 nM
For compound 4 the middle estimate is 3.3-fold (0.51 log units) above the measured one, within the range that was stated.
By their numbers in this assay, from the lowest: compounds 2 and 3 (each within the scatter of the next); then compound 4; then compound 1.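

In this assay, (trifluoromethyl)sulfonyl in place of ethoxy on an aromatic carbon, meta to a large group, gives an 11-fold lower number from compound 1 to compound 4 (1.02 log units; beyond the scatter) and stands as a large step. Within the data shown here, this is the first change that can be read in one place, as the earlier compounds differ from each other in several places at once and could not assign any difference to this aromatic carbon. Nothing available explains the size of this step or gives a reason for its direction.

From the compounds shown here alone, whether a nitrile or a methylsulfonyl group at this aromatic carbon would give a step of similar size remains open. Also open, going by these compounds, is whether the same exchange keeps its size when a shorter chain sits on the amide of the shared core.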